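Shifting the carboxylic acid on the benzyl group

A few compounds are considered here, and "the series" means these few. Any claim that something is new, unique, unknown or untested is made for them only; others in the source may bear on it.

Measured compounds:
compound 1 `CC(C)c1onc(-c2c(Cl)cccc2Cl)c1COc1ccc(N(C)Cc2cccc(C(=O)O)c2)c(C(F)(F)F)n1`: 89%
compound 2 `CN(Cc1cccc(C(=O)O)c1)c1ccc(OCc2c(-c3c(Cl)cccc3Cl)noc2C2CC2)nc1C(F)(F)F`: 79%

In a functional assay on HEK293 cells for agonist activity at Bile acid receptor (Homo sapiens) (a higher number here means a larger maximal response, a lower number a smaller maximal response), compound 1 gives 89% and compound 2 gives 79%. For the measured compounds named here, the only measured step, a number 10 percentage points lower from compound 1 to compound 2 (within the scatter), is within the scatter, so compound 2 stands level with compound 1 rather than apart from it. Compound 3 `CN(Cc1ccc(C(=O)O)cc1)c1ccc(OCc2c(-c3c(Cl)cccc3Cl)noc2C2CC2)nc1C(F)(F)F` differs from compound 2 by 4-carboxyphenyl in place of 3-carboxyphenyl on a saturated chain carbon bound to a nitrogen on an aromatic ring. Going by the values given here, no measured step touches this change; the one step known alters a different group and was itself within the scatter. The account therefore expects no step beyond the scatter, a number 4 percentage points lower from compound 2 to compound 3 (within the scatter), and estimates compound 3 at 75%, between 50% and 95%.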

Compound 3, largest response reached (reported as efficacy), in percent of the reference or control that the assay uses: 81%
For compound 3 the middle estimate is 6 percentage points below the measured one; the range from low to high includes it.
By their numbers in this assay, from the lowest: compounds 2, 3 and 1 (each within the scatter of the next).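

Exchanging 3-carboxyphenyl for 4-carboxyphenyl gives a number 2 percentage points higher from compound 2 to compound 3 (within the scatter) in this assay and so leaves the maximal response level. The earlier step altered a different group, whereas this pair shows that, with the cyclopropyl group in place, the carboxylic acid can occupy either of these two ring positions without a change beyond the scatter. Nothing at hand explains why the two compounds stand level. From the compounds shown here alone, whether 2-carboxyphenyl at this place, or a tetrazole in place of the carboxylic acid, would keep the response level stays open. So does whether the same exchange would read alike with the isopropyl group of compound 1.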